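The compounds below may be only part of what the source reports. "The series", "measured", "known", "first", "only" and "open" are said of these compounds alone.

Compound 3 `Cc1cc(OCc2nc(N)nc(NCC3(c4cccc(Cl)c4)CC3)n2)cc(N2CCCC2=O)c1` gives the highest number among the three measured compounds in an assay on COS-7 cells for agonist activity at Free fatty acid receptor 1 (Homo sapiens), read by scintillation counting and inositol phosphate accumulation, with a stated time of 90 min; a higher number here means that more compound is needed for the effect, a lower number that less compound is needed: compound 3 gives 48000 nM. Its nearest neighbour is compound 1 `Cc1ccc(Nc2nc(N)nc(COc3cccc(N4CCCC4=O)c3)n2)cc1Cl`, which in this assay gives 820 nM, and the furthest is compound 2 `Cc1cc(OCc2nc(N)nc(Nc3ccc(C)c(Cl)c3)n2)cc(N2CCCC2=O)c1`, which in this assay gives 20 nM. Two steps connect these numbers: a 41-fold lower number from compound 1 to compound 2 (1.61 log units; beyond the scatter), and a 2400-fold higher number from compound 2 to compound 3 (3.38 log units; beyond the scatter).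

Compound 4 `Cc1cc(OCc2nc(N)nc(NC3(Cc4cccc(Cl)c4)CC3)n2)cc(N2CCCC2=O)c1` is built from the same atoms as compound 3 but joined differently: 1-(3-chlorobenzyl)cyclopropyl in place of (1-(3-chlorophenyl)cyclopropyl)methyl on a nitrogen on an aromatic ring. Within the data shown here, only one measured step touches this part of the molecule, a 2400-fold higher number from compound 2 to compound 3 (3.38 log units; beyond the scatter), and it shows that what sits on this nitrogen can move the number very far. That step, however, exchanged an aromatic group for a chain-linked one, whereas the change to compound 4 merely rearranges the same pieces, so it offers no direct guide to direction. A step of some size in this assay is plausible either way, and a modest recovery is the more likely outcome given how far compound 3 sits from compound 2, yet the expected step of a 2.4-fold lower number from compound 3 to compound 4 (0.38 log units; beyond the scatter) is given with wide uncertainty. Compound 4 is therefore expected to give about 20000 nM in this assay, within a range from 3000 nM to 100000 nM.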

Compound 4, half-maximal effective concentration: 61000 nM
For compound 4 the middle estimate is 3.1-fold (0.48 log units) below the measured one, and the stated range covers the measured number.
By their numbers in this assay, from the lowest: compound 2; then compound 1; then compounds 3 and 4 (each within the scatter of the next).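

In this assay, putting 1-(3-chlorobenzyl)cyclopropyl in place of (1-(3-chlorophenyl)cyclopropyl)methyl on this nitrogen gives a 1.3-fold higher number from compound 3 to compound 4 (0.10 log units; within the scatter), so this rearrangement of the same atoms leaves the two compounds inseparable in this assay. Among these compounds, the replacement of 3-chloro-4-methylphenyl is now seen with a second group, and a 3100-fold higher number from compound 2 to compound 4 (3.48 log units; beyond the scatter) stands alongside a 2400-fold higher number from compound 2 to compound 3 (3.38 log units; beyond the scatter), so the large rise on leaving compound 2 is not particular to the one arrangement of compound 3. No evidence is available that accounts for the large rise seen with both groups or for the lack of a separation between them.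

The compounds shown leave open whether a simple 3-chlorobenzyl or 3-chlorophenyl on this nitrogen, without the cyclopropyl ring, would give a number close to that of compound 2 or one close to those of compound 3 and compound 4. They also leave open whether a group such as a cyclobutyl ring in place of the cyclopropyl ring, or a longer chain in place of the methylene of the benzyl group, would separate from compound 3 and compound 4 in this assay.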